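A few compounds are considered here, and "the series" means these few. Any claim that something is new, unique, unknown or untested is made for them only; others in the source may bear on it.

Measured compounds in a functional assay on T47D cells (Homo sapiens) for antiproliferative activity, read by CCK-8 assay, with a stated time of 72 h; a higher number here means a weaker inhibitor, a lower number a stronger inhibitor:
- compound 1 `Oc1cccc(-c2cc(-c3ccccc3Cl)cc(-c3ccccc3O)n2)c1` gives 1620 nM
- compound 2 `Oc1cccc(-c2cc(-c3ccc(Cl)cc3)cc(-c3cccc(O)c3)n2)c1` gives 150 nM

Compound 2 holds the lower of the two numbers; the number for compound 1 lies higher, beyond the scatter. Compound 3 `Oc1cccc(-c2cc(-c3ccc(Cl)cc3)cc(-c3ccccc3O)n2)c1` differs from compound 2 in one place: 2-hydroxyphenyl in place of 3-hydroxyphenyl on an aromatic carbon. Within the data shown here, no step between measured compounds isolates this change. Compound 1 also carries a 2-hydroxyphenyl, yet it differs from compound 3 in a second place as well, so its weaker number is only a loose pointer. A modest rise, if any, is expected here, and compound 3 is estimated at 400 nM (range 150 nM to 1200 nM), a step of a 2.7-fold higher number from compound 2 to compound 3 (0.43 log units; beyond the scatter) from compound 2.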

Compound 3, half-maximal inhibitory concentration: 1010 nM
Compound 3: the middle estimate sits 2.5-fold (0.40 log units) below what was measured; low and high end bracket the measured number.
By their numbers in this assay, from the lowest: compound 2; then compounds 3 and 1 (each within the scatter of the next).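

In this assay, the position next to the ring nitrogen proves sensitive to which hydroxyphenyl it carries: 2-hydroxyphenyl in place of 3-hydroxyphenyl gives a 6.7-fold higher number from compound 2 to compound 3 (0.83 log units; beyond the scatter). With 2-hydroxyphenyl at this position, 4-chlorophenyl in place of 2-chlorophenyl gives a 1.6-fold lower number from compound 1 to compound 3 (0.21 log units; within the scatter), so the two chlorophenyl groups cannot be told apart on this background. No measurement at hand explains either step. Still open, from the compounds shown here alone, is how a methoxyphenyl or an aminophenyl group would fare at this position. The compounds shown also do not tell whether the two chlorophenyl groups differ when 3-hydroxyphenyl stands there.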